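Cytotoxicity of three ureas and a fluoro analogue

A few compounds are considered here, and "the series" means these few. Any claim that something is new, unique, unknown or untested is made for them only; others in the source may bear on it.

The series shares the urea-linked core seen in compound 1 `COc1ccc(NC(=O)Nc2cc(C)nc3ccccc23)cc1F`, compound 2 `Cc1cc(NC(=O)Nc2ccc(O)cc2)c2ccccc2n1` and compound 3 `COC(=O)c1cccc(NC(=O)Nc2cc(C)nc3ccccc23)c1`, and all three have been tested in an ADME assay on Raji cells (Homo sapiens) for cytotoxicity, with a stated time of 72 h; on this read-out higher numbers stand for an effect only at larger amounts of compound and lower numbers for an effect already at smaller amounts. In this assay compound 1 reaches only the limit > 25000 nM. Compound 2 likewise stops at the limit > 25000 nM. Among the compounds with values here, compound 3 is the one compound with a number, giving 26000 nM in this assay, which puts it at the same height as the limit of > 25000 nM in this assay, at which 2 of the 3 values shown sit; nothing among the three separates them.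

Compound 4 `Cc1cc(NC(=O)Nc2cccc(F)c2)c2ccccc2n1` has not been tested. Compound 4 differs from compound 3 by fluoro in place of methoxycarbonyl on an aromatic carbon, with the new group sitting on an aromatic carbon of a six-membered aromatic ring of carbon only, meta to a large group. Within the data shown here, no measured pair covers a change of this kind, so no step size can be read from the data. Given that compound 3 sits at 26000 nM, the expectation is a step of no change at the digits printed from compound 3 to compound 4 (within the scatter) of no size beyond the scatter in this assay. Compound 4 is therefore estimated at 26000 nM, with a range from 12000 nM to 60000 nM, and a limit rather than a number is the likelier report.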

Compound 4, half-maximal effective concentration: > 25000 nM
Compound 4 was reported as a limit; the forecaster's own chance of this, stated with the estimate: 70%; the middle value lies beyond the limit too.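

In this assay, within the data shown here, compound 4 is reported only as the limit > 25000 nM and no step to it from compound 1, compound 2 or compound 3 can be read. The compounds shown leave open whether any change on the shared core alters cytotoxicity, with nearly all values resting at one point: the limit of > 25000 nM in this assay, at which 3 of the 4 values shown sit.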